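Methyl in Place of Nitro: Expected Potency of Compound 4

The source may report more compounds than this note shows. Statements on the series, on what has been measured and on what is new or still open speak of the compounds shown alone.

Measured so far in a functional assay on HCT-116 cells (Homo sapiens) for inhibition, read by MTT assay, with a stated time of 48 h; a higher number here means a weaker inhibitor, a lower number a stronger inhibitor:
compound 1, `COc1cc(-c2nccn3cc(-c4ccc(F)cc4)nc23)cc(OC)c1OC`: 263 nM
compound 2, `COc1cc(-c2nccn3cc(-c4ccc(O)cc4)nc23)cc(OC)c1OC`: 901 nM
compound 3, `COc1cc(-c2nccn3cc(-c4ccc([N+](=O)[O-])cc4)nc23)cc(OC)c1OC`: > 10000 nM

Compound 1 gives 263 nM in this assay and compound 2 gives 901 nM. Compound 3, by contrast, returns only a limit of the assay, > 10000 nM, and no number. Compound 3 therefore stands at the weak end of the three values shown: the step of an at least 38-fold higher number from compound 1 to compound 3 (1.58 log units; beyond the scatter) and the step of an at least 11-fold higher number from compound 2 to compound 3 (1.04 log units; beyond the scatter) are both beyond the scatter, and the limit of > 10000 nM in this assay, at which 1 of the 3 values shown sits, marks where compound 3 sits.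

Compound 4 `COc1cc(-c2nccn3cc(-c4ccc(C)cc4)nc23)cc(OC)c1OC` differs from compound 3 in a single place: methyl in place of nitro on an aromatic carbon. The measured steps that bear on this change are the two that lead into compound 3, an at least 38-fold higher number from compound 1 to compound 3 (1.58 log units; beyond the scatter) and an at least 11-fold higher number from compound 2 to compound 3 (1.04 log units; beyond the scatter), in which the nitro group entered and the number rose to the limit. The step to compound 4 removes the nitro group again, so a large fall in the number is expected, with compound 4 returning toward the range of compound 1 and compound 2. Compound 4 is estimated at 450 nM, within 150 nM to 1500 nM. That estimate means an expected at least 22-fold lower number from compound 3 to compound 4 (1.34 log units; beyond the scatter).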

Compound 4, half-maximal inhibitory concentration: 74 nM
The estimate for compound 4 lay 6.1-fold (0.78 log units) above the measured number; the measured number lies below the stated range.
By their numbers in this assay, from the lowest: compound 4; then compound 1; then compound 2. At a limit, above all of these: compound 3.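

The earlier compounds shown here showed only that, on this aromatic carbon para to a large group, fluoro gave a lower number than hydroxy or nitro; in this assay methyl now goes lower than all three, with a 3.6-fold lower number from compound 1 to compound 4 (0.55 log units; beyond the scatter) and a 12-fold lower number from compound 2 to compound 4 (1.09 log units; beyond the scatter). The change from nitro to methyl gives an at least 130-fold lower number from compound 3 to compound 4 (2.13 log units; beyond the scatter), so the shared core reaches its lowest number here with a group that has no hydrogen-bond donors or acceptors, and compound 4 is the most potent of the four. The size of that step is only a bound, since compound 3 stands at a limit of the assay and not at a number: the limit of > 10000 nM in this assay, at which 1 of the 4 values shown sits.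

With only four groups at this place, the compounds shown leave open whether an ethyl group, a methoxy group or a chlorine atom would match methyl or go lower still. They also leave open why methyl gives the lowest number, and whether the same order would hold with a change elsewhere on the shared core.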